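Working notes: chloro in place of hydrogen on the core

The source may report more compounds than this note shows. Statements on the series, on what has been measured and on what is new or still open speak of the compounds shown alone.

Measured so far in a functional assay on HCT-116 cells (Homo sapiens) for antiproliferative activity, read by MTT assay, with a stated time of 48 h; on this read-out higher numbers stand for weaker inhibition and lower numbers for stronger inhibition:
compound 1 `CCCCC(CCO)n1cnc2c(Cl)nc(F)nc21` - 13500 nM
compound 2 `CCCCC(CCO)n1cnc2c(Cl)ncnc21` - > 50000 nM (a limit, not a number)

Compound 2 has no number to start from. In this assay compound 2 gives > 50000 nM, which is a limit of the assay. Among the compounds with values here, the series so far shows (the limit of > 50000 nM in this assay, at which 1 of the 2 values shown sits).

Compound 3 `CCCCC(CCO)n1cnc2c(Cl)nc(Cl)nc21` differs from compound 2 as follows: chloro in place of hydrogen on an aromatic carbon. The new chloro sits on an aromatic carbon between two ring nitrogen atoms. Within the data shown here, one measured step bears on this change, at the same place: an at least 3.7-fold higher number from compound 1 to compound 2 (0.56 log units; beyond the scatter), with hydrogen in place of fluoro on an aromatic carbon. That step is beyond the scatter, and it marks compound 2, the hydrogen compound, as the weaker of the pair. Among the measured compounds shown here, no measured compound shows how chloro compares with fluoro here, so compound 1, at 13500 nM, is the only guide. Putting a halogen back on this carbon should therefore lower the number in this assay, although a result at the limit remains possible. The expected change is an at least 4.1-fold lower number from compound 2 to compound 3 (0.61 log units; beyond the scatter). For compound 3 the estimated value is 12000 nM, with an expected range of 5000 nM to 35000 nM.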

Compound 3, half-maximal inhibitory concentration: 15500 nM
For compound 3 the middle estimate is 1.3-fold (0.11 log units) below the measured one; the measured number falls inside the stated range.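

In this assay chloro in place of hydrogen on the aromatic carbon between two ring nitrogen atoms gives an at least 3.2-fold lower number from compound 2 to compound 3 (0.50 log units; beyond the scatter). This shows that the earlier difference between compound 1 and compound 2 is not confined to fluoro: both halogen compounds shown at this position give a measurable value, while the hydrogen compound does not. Within the data shown here, the direct comparison of the two halogens, a 1.1-fold higher number from compound 1 to compound 3 (0.06 log units; within the scatter) and within the scatter, adds what the earlier compounds could not show, namely that this assay does not separate chloro from fluoro at this position. From the compounds shown here alone, the size of the step from hydrogen stays open-ended, since the result for compound 2 is a limit of the assay and not a number: the limit of > 50000 nM in this assay, at which 1 of the 3 values shown sits.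

Whether this position accepts only a halogen remains open, as the compounds shown do not tell how bromo, a methoxy group or an amine on the same carbon would compare with chloro and fluoro. Going by these compounds, it also remains open whether the same order of hydrogen and halogen would hold with a longer chain in place of the one on the shared core.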